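Carboxy in Place of Methyl on the Amine Substituent

The compounds below may be only part of what the source reports. "The series", "measured", "known", "first", "only" and "open" are said of these compounds alone.

Compound 3 `CCCCCCCCCCCCCCC(COCc1ccccc1)NCC` gives 6000 nM in a functional assay on Jurkat cells (Homo sapiens) for inhibition (on this read-out lower numbers stand for stronger inhibition and higher numbers for weaker inhibition), the second highest of the three numbers measured; its nearest neighbour is compound 1 `CCCCCCCCCCCCCCC(N)CO` with 7000 nM, its furthest compound 2 `CCCCCCCCCCCCCCC(N)COCc1ccccc1` with 3000 nM, and both gaps lie within the scatter. Compound 4 `CCCCCCCCCCCCCCC(COCc1ccccc1)NCC(=O)O` differs from compound 3 by carboxy in place of methyl on a saturated chain carbon bound to an amine nitrogen. Among the measured compounds shown here, the one measured step on the amine nitrogen, a 2.0-fold higher number from compound 2 to compound 3 (0.30 log units; within the scatter), stayed within the scatter, while a 2.3-fold lower number from compound 1 to compound 2 (0.37 log units; beyond the scatter) concerns the oxygen and bears less on this change. For the measured compounds named here, no measured step introduces a carboxy group, so the expected step in this assay is no change at the digits printed from compound 3 to compound 4 (within the scatter), none beyond the scatter. For compound 4 the estimated value is 6000 nM, with a range from 2000 nM to 18000 nM.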

Compound 4, half-maximal inhibitory concentration: 3000 nM
Beside the measured number, compound 4's estimate is 2.0-fold (0.30 log units) above it, and the stated range covers the measured number.
By their numbers in this assay, from the lowest: compounds 2, 4, 3 and 1 (each within the scatter of the next, the first and the last beyond it).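

In this assay the carboxy group is accepted at this place, on a saturated chain carbon bound to an amine nitrogen: the result reads a 2.0-fold lower number from compound 3 to compound 4 (0.30 log units; within the scatter) and, against the unsubstituted amine, no change at the digits printed from compound 2 to compound 4 (within the scatter) for carboxymethyl on that nitrogen. Hydrogen, ethyl and carboxymethyl on the amine nitrogen thus all sit within the scatter of one another, so this position shows no measurable preference among them. Nothing at hand accounts for this level read-out. From the compounds shown here alone, whether an amide, a methyl ester or a longer carboxylic acid chain on the nitrogen would read the same stays open.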